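The source may report more compounds than this note shows. Statements on the series, on what has been measured and on what is new or still open speak of the compounds shown alone.

Working notes on the series. Compound 1 `Nc1cc(N)c2nc(-c3ccccc3)c(Oc3ccc(Cl)c(Cl)c3)nc2c1` is the starting point of this step. In a functional assay on NCI/ADR-RES cells (Homo sapiens) for inhibition, read by sulforhodamine B assay, with a stated time of 48 h (on this read-out lower numbers stand for higher toxicity in this test and higher numbers for lower toxicity in this test), compound 1 gives < 100000 nM, which is a limit of the assay rather than a number. Compound 2 `Nc1cc(N)c2nc(-c3ccccc3)c(NCc3ccc(Cl)c(Cl)c3)nc2c1` belongs to the same series. In this assay compound 2 gives < 100000 nM, again a limit. Compound 3 `CCOC(=O)[C@H](CCC(=O)O)NC(=O)c1ccc(Sc2nc3cc(N)cc(N)c3nc2-c2ccccc2)cc1` completes the measured set. In this assay compound 3 gives < 100000 nM, also a limit. Thus compound 1 stands exactly where the other two stand: the limit of < 100000 nM in this assay, at which 3 of the 3 values shown sit. No measured step between any two of these compounds can be drawn, so nothing on the size of any structural change within the series is known from these numbers.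

Compound 4 `Nc1cc(N)c2nc(-c3ccccc3)c(Sc3ccc(F)cc3)nc2c1` is the next compound to be measured. It differs from compound 1 in one place: (4-fluorophenyl)sulfanyl in place of 3,4-dichlorophenoxy on an aromatic carbon. Within the data shown here, with every measured value sitting at the same limit, there is no measured step from which the direction or size of this change in this assay could be read; the expectation is therefore for no step beyond the usual scatter, with compound 4 expected to fall in the same region as compound 1. The expected step from compound 1 to compound 4 is a step that the limit leaves unreadable from compound 1 to compound 4. For compound 4 in this assay the estimate is 20000 nM, with an expected range from 3000 nM to 90000 nM.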

Compound 4, concentration lethal to 50% of the cells: 72400 nM
Beside the measured number, compound 4's estimate is 3.6-fold (0.56 log units) below it, within the range that was stated.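

No step can be read between compound 1 and compound 4, because compound 1 carries only a limit of the assay: the limit of < 100000 nM in this assay, at which 3 of the 4 values shown sit.

The compounds shown leave open how large the effect on this read-out is of (4-fluorophenyl)sulfanyl in place of 3,4-dichlorophenoxy, and whether any single change on the shared core moves it beyond the usual scatter.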